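The source may report more compounds than this note shows. Statements on the series, on what has been measured and on what is new or still open speak of the compounds shown alone.

Measured so far in a functional assay on PC-3 cells (Homo sapiens) for cytotoxicity, read by sulforhodamine B assay, with a stated time of 72 h; on this read-out higher numbers stand for weaker inhibition of growth and lower numbers for stronger inhibition of growth:
- compound 1 `O=C(Nc1ccccc1O)C1CCc2ccccc2N1` gives 4310 nM
- compound 2 `O=C(Nc1ccccc1O)C1CCc2ccccc2N1C(=O)c1ccccc1` gives 5690 nM
- compound 3 `O=C(Nc1ccccc1O)C1CCc2ccccc2N1C(=O)c1ccccc1Cl` gives 60000 nM

Compound 3 has the highest number of the three; its nearest neighbour is compound 2, and the gap to compound 1 is wider still, with both gaps beyond the scatter. Compound 4 `O=C(Nc1ccccc1O)C1CCc2ccccc2N1C(=O)c1ccc(Cl)cc1` keeps the same atoms but joins them differently: 4-chlorophenyl in place of 2-chlorophenyl on a carbonyl carbon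

Within the data shown here, two measured steps bear on this. The step of a 1.3-fold higher number from compound 1 to compound 2 (0.12 log units; within the scatter) shows that the unsubstituted benzoyl on the ring nitrogen changes little, while the step of an 11-fold higher number from compound 2 to compound 3 (1.02 log units; beyond the scatter) shows that placing chloro on an aromatic carbon of that benzoyl raises the number strongly; the step of a 14-fold higher number from compound 1 to compound 3 (1.14 log units; beyond the scatter) repeats the same picture. Among the measured compounds shown here, no measured pair moves the chlorine from one position to another, so how much of that rise survives in compound 4 is not known from these data. The expectation is that compound 4 falls back toward compound 2, with a downward step a 4.0-fold lower number from compound 3 to compound 4 (0.60 log units; beyond the scatter) likely beyond the scatter. Compound 4 is therefore estimated at 15000 nM, within the range 4500 nM to 60000 nM.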

Compound 4, concentration for 50% growth inhibition: 25100 nM
Compound 4: middle estimate off by 1.7-fold (0.22 log units), on the low side; low and high end bracket the measured number.
By their numbers in this assay, from the lowest: compounds 1 and 2 (each within the scatter of the next); then compound 4; then compound 3.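

In this assay, among these compounds, the place of the chlorine on the benzoyl group matters: 4-chlorophenyl in place of 2-chlorophenyl on the carbonyl carbon gives a 2.4-fold lower number from compound 3 to compound 4 (0.38 log units; beyond the scatter) and is the first measured move of the chlorine from one position to another. The move does not remove the rise that comes with chloro, since chloro in place of hydrogen on an aromatic carbon still gives a 4.4-fold higher number from compound 2 to compound 4 (0.64 log units; beyond the scatter) and the whole (4-chlorophenyl)carbonyl in place of hydrogen on the ring nitrogen gives a 5.8-fold higher number from compound 1 to compound 4 (0.77 log units; beyond the scatter) in this series. Nothing measured here explains why the position of the chlorine changes the number.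

The compounds shown leave open whether the rise is specific to chloro or would also follow from fluoro, methoxy or an amine on the same ring. They also leave open how a carboxylic acid there would read.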